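Aryl swap on the oxadiazoline series: dichloro to dimethoxy

A few compounds are considered here, and "the series" means these few. Any claim that something is new, unique, unknown or untested is made for them only; others in the source may bear on it.

Measured so far in a functional assay on BGC-823 cells (Homo sapiens) for antiproliferative activity, read by MTT assay, tested at 5 uM; a lower number here means a weaker effect, a higher number a stronger effect of the compound at the concentration tested:
compound 1 `COc1cc(C2=NN(C(C)=O)C(c3ccc(F)c(F)c3)O2)cc(OC)c1OC` gives 21.6%
compound 2 `COc1cc(C2=NN(C(C)=O)C(c3ccc(F)cc3)O2)cc(OC)c1OC` gives 13.3%
compound 3 `COc1cc(C2=NN(C(C)=O)C(c3cc(Cl)cc(Cl)c3)O2)cc(OC)c1OC` gives 6.6%

Compound 3 stands lowest of the three in this assay; its gap to compound 1 is beyond the scatter, its gap to compound 2 within it. The next compound, compound 4 `COc1ccc(OC)c(C2OC(c3cc(OC)c(OC)c(OC)c3)=NN2C(C)=O)c1`, differs from compound 3 by 2,5-dimethoxyphenyl in place of 3,5-dichlorophenyl on a saturated ring carbon. Within the data shown here, the steps that bear on this are the two earlier aryl exchanges at the same saturated ring carbon: a number 15 percentage points lower from compound 1 to compound 3 (beyond the scatter) and a number 6.7 percentage points lower from compound 2 to compound 3 (within the scatter). Both were small, so the exchange of one aryl ring for another has so far moved the read-out only modestly, and nothing in the series addresses methoxy groups on this ring. Compound 4 is therefore expected close to compound 3, with no step beyond the scatter, the estimated step being a number 5.4 percentage points higher from compound 3 to compound 4 (within the scatter). Compound 4 is estimated at 12%, within 0% to 30%.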

Compound 4, a percentage reported as inhibition, at one concentration (the size of the read-out at that concentration, not a potency): 18.2%
Compound 4: the middle estimate sits 6.2 percentage points below what was measured; the range from low to high includes it.
By their numbers in this assay, from the lowest: compounds 3, 2, 4 and 1 (each within the scatter of the next, the first and the last beyond it).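

Replacing halogen with methoxy on the aryl ring at this saturated ring carbon still leaves a measurable read-out in this assay: the change gives a number 11.6 percentage points higher from compound 3 to compound 4 (beyond the scatter). Against the two fluorinated compounds, the same position shows a number 4.9 percentage points higher from compound 2 to compound 4 (within the scatter) and a number 3.4 percentage points lower from compound 1 to compound 4 (within the scatter), so halogen on this ring is not required to stay within the scatter of them. No evidence on hand accounts for these steps.

Which of the two methoxy groups matters stays open, since neither appears alone. Also open, from the compounds shown here alone, is how an amine or a carboxylic acid on this ring would read.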